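Expected Effect of a 3-(Trifluoromethyl)phenyl Group on Cell Growth

The source may hold more compounds than are shown below. What is called first, only, known or untested is meant among the compounds shown, and "the series" means these compounds.

The measured compounds are three. Compound 1, `COc1cc(Cl)cc(-c2nn(-c3cccc(NC(=O)Nc4ccc(Cl)c(C(F)(F)F)c4)c3)cc2-c2ccncc2)c1`, gives 35% in a functional assay on HCT-15 cells (Homo sapiens) for inhibition, read by sulforhodamine B assay, with a stated time of 48 h, tested at 1 uM; a lower number here means a stronger effect, a higher number a weaker effect of the compound at the concentration tested. Compound 2, `COc1cc(Cl)cc(-c2nn(-c3cccc(NC(=O)Nc4cc(C(F)(F)F)cc(C(F)(F)F)c4)c3)cc2-c2ccncc2)c1`, gives 17% in this assay. Compound 3, `COc1cc(Cl)cc(-c2nn(-c3cccc(NC(=O)Nc4ccc(Cl)c(Cl)c4)c3)cc2-c2ccncc2)c1`, gives 77% in this assay.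

Compound 3 thus stands highest of the three numbers: compound 1 is lower by a margin beyond the scatter, and compound 2 lies further down still. Compound 4, `COc1cc(Cl)cc(-c2nn(-c3cccc(NC(=O)Nc4cccc(C(F)(F)F)c4)c3)cc2-c2ccncc2)c1`, has not yet been measured. It differs from compound 3 in one place: 3-(trifluoromethyl)phenyl in place of 3,4-dichlorophenyl on an amide-type nitrogen. Among the measured compounds shown here, the one measured step that bears on this change is a number 42 percentage points higher from compound 1 to compound 3 (beyond the scatter), a large step with the two groups moving the other way round. Compound 4 carries the trifluoromethyl of compound 1 but lacks the chloro of compound 1, so its number is expected to fall between those of compound 1 and compound 3 rather than to match either. The step is expected to be a number 27 percentage points lower from compound 3 to compound 4 (beyond the scatter), that is, downward and beyond the scatter. Compound 4 is therefore estimated to give 50% in this assay, with a range from 25% to 78%.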

Compound 4, a percentage reported as activity, at one concentration (the size of the read-out at that concentration, not a potency): 57%
Compound 4: middle estimate off by 7 percentage points, on the low side; the range from low to high includes it.
By their numbers in this assay, from the lowest: compound 2; then compound 1; then compound 4; then compound 3.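

In this assay, the change on the amide-type nitrogen to 3-(trifluoromethyl)phenyl from 3,4-dichlorophenyl gives a number 20 percentage points lower from compound 3 to compound 4 (beyond the scatter) and so shows that a lone trifluoromethyl on this ring, with no chloro, is enough for a stronger effect than the 3,4-dichlorophenyl gives. The same compound also shows what the added group on the 3-(trifluoromethyl)phenyl ring contributes: hydrogen in place of chloro gives a number 22 percentage points higher from compound 1 to compound 4 (beyond the scatter) as a modest loss of effect, while hydrogen in place of the further trifluoromethyl gives a number 40 percentage points higher from compound 2 to compound 4 (beyond the scatter) as a large one. Among these four compounds a further group lowers the number only where a trifluoromethyl is kept, and compound 3, whose 3,4-dichlorophenyl carries no trifluoromethyl, goes against any broader reading, since it has the highest number of the set.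

Nothing measured here explains why these steps differ in size. As far as these compounds go, whether a nitrile, a methoxy group or an amine in place of the trifluoromethyl would keep the effect remains open, as does the effect of the unsubstituted phenyl on this nitrogen.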